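This account rests on a few compounds, and the source may have more. Where it says the series, first, only, none or still open, it means among the compounds named here.

Compound 1: `COc1cccc(-c2nc(SCC(=O)c3sc(-c4ccccc4)nc3C)[nH]c(=O)c2C#N)c1` — 99%
Compound 2: `Cc1nc(-c2ccc(Cl)cc2)sc1C(=O)CSc1nc(-c2ccc(Cl)cc2)c(C#N)c(=O)[nH]1` — 99%

In a functional assay on U-87MG ATCC cells for antiproliferative activity against U-87 MG (Homo sapiens), read by MTT assay, with a stated time of 48 h, tested at 5 uM (on this read-out higher numbers stand for a weaker effect at the one concentration tested and lower numbers for a stronger effect), compound 1 gives 99%. Compound 2 gives 99% in this assay, so compound 2 stands level with compound 1, the two numbers lying within the usual scatter. Compound 3, `COc1cccc(-c2nc(SCC(=O)c3sc(-c4ccc(Cl)cc4)nc3C)[nH]c(=O)c2C#N)c1`, carries the change (3-methoxyphenyl in place of 4-chlorophenyl on an aromatic carbon). Among the compounds with values here, no measured pair shows this exact change, but compound 1 already carries the entering group at the same place and reads no differently from compound 2. The step from compound 2 to compound 3 is therefore expected to be a number 1 percentage points lower from compound 2 to compound 3 (within the scatter), nothing beyond the scatter. Compound 3 is estimated at 98%, with a range from 85% to 105%.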

Compound 3, a percentage reported as activity, at one concentration (the size of the read-out at that concentration, not a potency): 96.6%
The estimate for compound 3 lay 1.4 percentage points above the measured number, and the stated range covers the measured number.
By their numbers in this assay, from the lowest: compounds 3, 1 and 2 (each within the scatter of the next).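

Replacing 4-chlorophenyl with 3-methoxyphenyl at this place in this assay gives a number 2.4 percentage points lower from compound 2 to compound 3 (within the scatter) and so shows directly that this swap does not separate the compounds. Chloro in place of hydrogen on an aromatic carbon gives a number 2.4 percentage points lower from compound 1 to compound 3 (within the scatter) and so adds a second change that also stays within the scatter. Nothing available explains why these numbers stay together.

Going by these compounds, whether an amine or a carboxylic acid at this place would move the number beyond the scatter remains open. So does how these compounds behave at other concentrations.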